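A few compounds are considered here, and "the series" means these few. Any claim that something is new, unique, unknown or untested is made for them only; others in the source may bear on it.

Compound 1 `C/C1=C/CC[C@@]2(C)O[C@@H]2[C@H]2OC(=O)[C@@H](CN3CCCCC3)[C@@H]2CC1`: 840 nM
Compound 2 `C/C1=C/CC[C@@]2(C)O[C@@H]2[C@H]2OC(=O)[C@@H](CN3CCC(F)CC3)[C@@H]2CC1`: 1770 nM
Compound 3 `C/C1=C\CC[C@@]2(C)O[C@@H]2[C@H]2OC(=O)[C@@H](CN3CCC(F)(F)CC3)[C@@H]2CC1`: 690 nM
Compound 4 `C/C1=C/CC[C@@]2(C)O[C@@H]2[C@H]2OC(=O)[C@@H](CN3CCC(C(F)(F)F)CC3)[C@@H]2CC1`: not yet measured

In a functional assay on HL-60 cells (Homo sapiens) for antiproliferative activity, read by MTT assay, with a stated time of 72 h (on this read-out higher numbers stand for weaker inhibition of growth and lower numbers for stronger inhibition of growth), compound 2 has the highest number of the three, at 1770 nM, and so the weakest growth inhibition among them. Compound 4 changes one group of compound 2: trifluoromethyl in place of fluoro on a saturated ring carbon. This puts trifluoromethyl in place of fluoro on a saturated ring carbon.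

Within the data shown here, only one measured step is a single change at this ring carbon: a 2.1-fold higher number from compound 1 to compound 2 (0.32 log units; beyond the scatter), seen when fluoro replaces hydrogen. Among the measured compounds shown here, it is modest, and no measured compound carries trifluoromethyl. Compound 3, with two fluoro groups on that carbon, differs from compound 2 in more than one place. Compound 3 gives 690 nM, which lies within the usual scatter of compound 1 at 840 nM, so adding fluorine does not raise the number in every case here.

The expected step is therefore a 1.5-fold lower number from compound 2 to compound 4 (0.17 log units; within the scatter), a modest move to a lower number that may not clear the scatter. For compound 4 the estimated value is 1200 nM, with an expected range from 500 nM to 3000 nM.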

Compound 4, concentration for 50% growth inhibition: 1000 nM
Estimate against measurement, compound 4: 1.2-fold (0.08 log units) above; the measured number falls inside the stated range.
By their numbers in this assay, from the lowest: compounds 3, 1, 4 and 2 (each within the scatter of the next, the first and the last beyond it).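

In this assay the swap to trifluoromethyl, with four heavy atoms where fluoro has one, gives a 1.8-fold lower number from compound 2 to compound 4 (0.25 log units; within the scatter) and, set against plain hydrogen, a 1.2-fold higher number from compound 1 to compound 4 (0.08 log units; within the scatter) as well. This ring carbon, three ring bonds from the ring nitrogen, therefore carries a much bigger group than fluoro without a shift from hydrogen that clears the scatter. Among these compounds, the number does not simply climb as heavy atoms are added here, since among hydrogen, fluoro and trifluoromethyl only the step from compound 1 to compound 2 lies beyond the scatter.

From the compounds shown here alone, whether a methyl, a hydroxyl or a nitrile on the same carbon would also stay within the scatter of compound 1 remains open. Among the compounds shown here, nothing available explains why the single fluoro of compound 2 alone stands apart.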